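A few compounds are considered here, and "the series" means these few. Any claim that something is new, unique, unknown or untested is made for them only; others in the source may bear on it.

Compound 1 `C[C@@H]1CCCN1c1c(C#N)c2c(N)nc(Nc3cn[nH]c3)nc2n1C` gives 0.4 nM
Compound 2 `C[C@@H]1CCCN1c1c(C#N)c2c(N)nc(N)nc2n1C` gives 13 nM
Compound 3 `C[C@@H]1CCCN1c1c(C#N)c2c(N)nc(Nc3cnn(C)c3)nc2n1C` gives 0.3 nM

All three numbers come from an assay on isolated protein for binding affinity to Leucine-rich repeat serine/threonine-protein kinase 2 variant G2019S (Homo sapiens), read by TR-FRET and LanthaScreen, with a stated time of 2 h; on this read-out higher numbers stand for weaker inhibition and lower numbers for stronger inhibition. Compound 3 shows the lowest number of the three, but the step of a 1.3-fold lower number from compound 1 to compound 3 (0.12 log units; within the scatter) lies within the scatter, so compound 3 and compound 1 cannot be told apart. The step of a 43-fold lower number from compound 2 to compound 3 (1.64 log units; beyond the scatter) is large, as is a 33-fold higher number from compound 1 to compound 2 (1.51 log units; beyond the scatter): the pyrazole on the ring nitrogen is what separates compound 2 from the other two.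

Compound 4 `Cc1n[nH]cc1Nc1nc(N)c2c(C#N)c(N3CCC[C@H]3C)n(C)c2n1` differs from compound 3 by 3-methyl-1H-pyrazol-4-yl in place of 1-methyl-1H-pyrazol-4-yl on a nitrogen on an aromatic ring; the methyl moves from the ring nitrogen to a ring carbon, so the ring again carries a hydrogen on its nitrogen, as in compound 1. The step that bears on this is a 1.3-fold lower number from compound 1 to compound 3 (0.12 log units; within the scatter), which shows that the hydrogen and the methyl on the ring nitrogen give numbers within the scatter. For the measured compounds named here, no measured step places a methyl on the ring carbon, so that part is untested. The expected step is therefore small, a 2.0-fold higher number from compound 3 to compound 4 (0.30 log units; within the scatter), with an estimate for compound 4 in this assay of 0.6 nM, from 0.2 nM to 2.5 nM.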

Compound 4, inhibition constant: 2 nM
Compound 4: the middle estimate sits 3.3-fold (0.52 log units) below what was measured; the range from low to high includes it.
By their numbers in this assay, from the lowest: compounds 3 and 1 (each within the scatter of the next); then compound 4; then compound 2.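

For the compounds shown here, putting a methyl on a ring carbon of the pyrazole is the first change to the pyrazole itself that moves the number beyond the scatter: adding it gives a 5.0-fold higher number from compound 1 to compound 4 (0.70 log units; beyond the scatter), and moving the methyl from the ring nitrogen to a ring carbon gives a 6.7-fold higher number from compound 3 to compound 4 (0.82 log units; beyond the scatter). So at this position, where the methyl sits on the pyrazole matters, whereas the methyl on the ring nitrogen did not. The 3-methyl-1H-pyrazol-4-yl group still improves on plain hydrogen, with a 6.5-fold lower number from compound 2 to compound 4 (0.81 log units; beyond the scatter), and nothing available explains why the two methyl placements differ.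

As far as these compounds go, it remains open how an ethyl or a chlorine on that same ring carbon would compare with the methyl. Also open, from the compounds shown here alone, is whether a phenyl or pyridine ring on this nitrogen could take the place of the pyrazole.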